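Taking the methoxy group off compound 3

The compounds below may be only part of what the source reports. "The series", "measured", "known", "first", "only" and "open" are said of these compounds alone.

Compound 1 `CNC(=O)c1cc(Oc2ccc(C3=NNC(c4cccc(Br)c4)C3)cc2)ccn1` reads 3540 nM
Compound 2 `CNC(=O)c1cc(Oc2ccc(C3=NNC(c4ccc(F)cc4Cl)C3)cc2)ccn1` reads 24300 nM
Compound 3 `CNC(=O)c1cc(Oc2ccc(C3=NNC(c4ccc(OC)cc4)C3)cc2)ccn1` reads 7740 nM

These three values come from a functional assay on PC-3 cells (Homo sapiens) for cytotoxicity, read by MTT assay, with a stated time of 72 h (a higher number here means a weaker inhibitor, a lower number a stronger inhibitor), and the compounds differ only in the group on a saturated ring carbon. Compound 3 stands second highest of the three, with compound 1 lower and compound 2 higher. The measured steps that reach it are a 2.2-fold higher number from compound 1 to compound 3 (0.34 log units; beyond the scatter) and a 3.1-fold lower number from compound 2 to compound 3 (0.50 log units; beyond the scatter) and both are modest.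

Compound 4 `CNC(=O)c1cc(Oc2ccc(C3=NNC(c4ccccc4)C3)cc2)ccn1` has not yet been measured. It carries hydrogen in place of methoxy on an aromatic carbon, para to a large group, which turns 4-methoxyphenyl into phenyl hydrogen in place of methoxy on an aromatic carbon and leaves the rest of compound 3 unchanged.

Going by the values given here, no measured pair isolates this change. The closest evidence is the exchange of whole groups at the same place, and the largest such exchange is a 6.9-fold higher number from compound 1 to compound 2 (0.84 log units; beyond the scatter) which is also modest. As far as these compounds go, a step of no more than modest size is therefore expected, the direction remains open, and the most likely outcome is none beyond the scatter. The expected change is a 1.1-fold higher number from compound 3 to compound 4 (0.04 log units; within the scatter) as estimated here. For compound 4 the estimated value is 8500 nM with an expected range from 3000 nM to 22000 nM in this assay.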

Compound 4, half-maximal inhibitory concentration: 4520 nM
Beside the measured number, compound 4's estimate is 1.9-fold (0.27 log units) above it, within the range that was stated.
By their numbers in this assay, from the lowest: compounds 1, 4 and 3 (each within the scatter of the next, the first and the last beyond it); then compound 2.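

In this assay, going by these compounds alone, the phenyl of compound 4 gives the first direct reading of this change: hydrogen in place of methoxy, para to a large group, is a 1.7-fold lower number from compound 3 to compound 4 (0.23 log units; within the scatter), so the methoxy group is not needed to hold the reading at this place, and hydrogen in place of bromo is likewise a 1.3-fold higher number from compound 1 to compound 4 (0.11 log units; within the scatter). Among these compounds, only the 2-chloro-4-fluorophenyl group stands clearly apart from plain phenyl, with a 5.4-fold lower number from compound 2 to compound 4 (0.73 log units; beyond the scatter), although compound 1 and compound 3 remain separated by a 2.2-fold higher number from compound 1 to compound 3 (0.34 log units; beyond the scatter) even though each lies within the scatter of compound 4. No measurement offered here explains any of these readings.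

The compounds shown leave open whether the gap at compound 2 belongs to the chlorine, the fluorine or the two together, since neither a 2-chlorophenyl nor a 4-fluorophenyl group stands among them. They also do not tell how this position would read with an amine or a carboxylic acid on the ring, or with a saturated ring such as cyclohexyl in place of phenyl.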